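The compounds below may be only part of what the source reports. "The series", "measured", "known", "first", "only" and "open" are said of these compounds alone.

Working notes on the series. Compound 3 `CC(C)(C)c1ccc(-c2ccc3c(NCCCNCc4ccco4)ccnc3c2)cc1` holds the highest number of the three measured: in a physicochemical assay for solubility, with a stated time of 18 h, at pH 7.4 (a lower number here means a less soluble compound, a higher number a more soluble compound), compound 3 gives 32000 nM. Compound 1 `COc1cccc(CNCCCNc2ccnc3cc(Oc4ccc(Cl)cc4)ccc23)c1O` gives 14500 nM, and compound 2 `COc1cccc(CNCCCNc2ccnc3cc(Cc4ccccc4)ccc23)c1O` gives 4200 nM. Going by the values given here, the one measured step, a 3.5-fold lower number from compound 1 to compound 2 (0.54 log units; beyond the scatter), concerns the aryl group on the shared core and does not touch the amine side. Compound 4 `COc1cccc(CNCCCNc2ccnc3cc(-c4ccc(C(C)(C)C)cc4)ccc23)c1O` differs from compound 3 by 2-hydroxy-3-methoxyphenyl in place of furan-2-yl on a saturated chain carbon bound to an amine nitrogen. Among the compounds with values here, no measured step covers this change; compounds 1 and 2 carry the entering group but on a different aryl. Expected: a small fall in this assay, a 1.8-fold lower number from compound 3 to compound 4 (0.25 log units; within the scatter), not clearly beyond the scatter. Compound 4 is estimated at 18000 nM, with a range of 6000 nM to 45000 nM.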

Compound 4, solubility: 32000 nM
Compound 4: the middle estimate sits 1.8-fold (0.25 log units) below what was measured; the measured number falls inside the stated range.
By their numbers in this assay, from the lowest: compound 2; then compound 1; then compounds 3 and 4 (each within the scatter of the next).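

Read in this assay the amine side now has a step of its own: there is no change at the digits printed from compound 3 to compound 4 (within the scatter) for 2-hydroxy-3-methoxyphenyl in place of furan-2-yl on a saturated chain carbon bound to an amine nitrogen. With that amine side held, 4-(tert-butyl)phenyl on an aromatic carbon gives a 7.6-fold higher number from compound 2 to compound 4 (0.88 log units; beyond the scatter) in place of benzyl, and a 2.2-fold higher number from compound 1 to compound 4 (0.34 log units; beyond the scatter) in place of 4-chlorophenoxy. No evidence on hand bears on these steps.

As far as these compounds go, whether the furan-2-yl exchange reads the same with benzyl or 4-chlorophenoxy on the core remains open. So does the outcome with a piperidine or a longer chain on the amine side.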